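Swapping the Aromatic Group on the Amide Nitrogen

This account rests on a few compounds, and the source may have more. Where it says the series, first, only, none or still open, it means among the compounds named here.

Of the compounds shown here, two built on a shared core have been measured so far. Compound 1 `O=C(/C=C/c1coc2cc(O)ccc2c1=O)NCc1ccccc1` is tested in a functional assay (QGY7701 cells, Homo sapiens) for inhibition, read by MTT assay, with a stated time of 48 h (on this read-out higher numbers stand for weaker inhibition and lower numbers for stronger inhibition), and gives 63000 nM. Compound 2 `COc1cccc(NC(=O)/C=C/c2coc3cc(OC)ccc3c2=O)c1` is the other measured member; in this assay compound 2 gives 39100 nM. That is the lower of the two numbers, but its gap to compound 1 lies within the usual scatter of this measurement, so the two compounds cannot be ranked against each other on present evidence.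

Compound 3 `COc1ccc2c(=O)c(/C=C/C(=O)Nc3ccc(F)cc3)coc2c1` has not yet been measured. It differs from compound 2 in one place: 4-fluorophenyl in place of 3-methoxyphenyl on an amide-type nitrogen. Within the data shown here, no measured pair shows what such a swap does here, so the direction is unknown, and the expected step is a 1.0-fold higher number from compound 2 to compound 3 (0.01 log units; within the scatter), no larger than the scatter. Compound 3 is accordingly estimated to give about 40000 nM in this assay, with a likely range from 15000 nM to 100000 nM.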

Compound 3, half-maximal inhibitory concentration: > 100000 nM
Compound 3 gave a limit, no number; the forecaster's own chance of this, stated with the estimate: 20%; middle value at least 2.5-fold (0.39 log units) from the limit.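

Among these compounds, the group on the amide-type nitrogen clearly matters in this assay: 4-fluorophenyl in place of 3-methoxyphenyl gives an at least 2.5-fold higher number from compound 2 to compound 3 (0.40 log units; beyond the scatter), the only step so far between compounds differing in one place. Since higher numbers stand for weaker inhibition, this single swap weakens inhibition, which the gap between compound 1 and compound 2 could not show. The result for compound 3 is a limit of the assay and not a number: the limit of > 100000 nM in this assay, at which 1 of the 3 values shown sits.

The swap removes the methoxy group and adds a fluorine at a different numbered ring position, so these compounds cannot separate the roles of the two groups or of their placement. From the compounds shown here alone, how a plain phenyl, or a phenyl carrying an amine or a carboxylic acid, would behave on this nitrogen also remains open.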